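Swapping a Pyrrolidine Amide for an Acylsulfonamide

The source may hold more compounds than are shown below. What is called first, only, known or untested is meant among the compounds shown, and "the series" means these compounds.

Compound 1 `Cc1cc(C)cc(S(=O)(=O)c2c(C(=O)N[C@@H]3CCNC3)[nH]c3ccc(Cl)cc23)c1` was tested in an ADME assay on MT4 cells (Homo sapiens) for cytotoxicity, read by MTT assay, with a stated time of 5 days (a lower number here means that less compound is tolerated, a higher number that more compound is tolerated), where compound 1 gives 37300 nM. Going by the values given here, that is the only plain number in this small set. A related compound, compound 2 `Cc1cc(C)cc(S(=O)(=O)c2c(C(=O)NC3CN(Cc4ccccc4C#N)C3)[nH]c3ccc(Cl)cc23)c1`, reaches only a limit of the assay, > 234000 nM, so no number is known for it. the limit of > 234000 nM in this assay, at which 1 of the 2 values shown sits, marks where that limit sits, and compound 1 therefore stands alone as the single measured point against which anything new can be judged.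

Compound 3 `CCS(=O)(=O)NC(=O)c1[nH]c2ccc(Cl)cc2c1S(=O)(=O)c1cc(C)cc(C)c1` is not yet measured. It differs from compound 1 in one place: ethylsulfonyl in place of pyrrolidin-3-yl on an amide-type nitrogen. Among the compounds with values here, no pair of measured compounds shows a step of this kind, so the direction of the change cannot be read off from what is already known.

Compound 3 is expected to sit near 80000 nM, estimated between 20000 nM and 250000 nM. The expected step of a 2.1-fold higher number from compound 1 to compound 3 (0.33 log units; beyond the scatter) is modest, leaning toward more compound being tolerated rather than less, and there is a fair chance that the assay returns only a limit for compound 3 rather than a number.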

Compound 3, half-maximal cytotoxic concentration: > 283000 nM
Compound 3: no number, only a limit (the forecaster's own chance of this, stated with the estimate: 35%); middle value at least 3.5-fold (0.54 log units) from the limit.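

In this assay, ethylsulfonyl in place of pyrrolidin-3-yl on the amide-type nitrogen gives an at least 7.5-fold higher number from compound 1 to compound 3 (0.88 log units; beyond the scatter). Going by these compounds alone, for compound 3 the assay returns a limit and not a number: the limit of > 283000 nM in this assay, at which 1 of the 3 values shown sits. This is the first step that can be read at this position, and it shows that the change moves the read-out beyond the usual scatter, toward more compound being tolerated, so the pyrrolidin-3-yl group is not needed for the higher number.

Going by these compounds, the swap removes a five-membered non-aromatic ring and its stereocentre and brings in an open chain with a sulfonyl group all at once, so this single step cannot tell which part of the change matters, and how far the true value of compound 3 lies past its limit also stays unknown. Whether a simple open-chain amine such as 2-aminoethyl, or a longer chain on the sulfonyl such as butylsulfonyl, on the same nitrogen would shift the read-out in the same direction remains an open question.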